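What losing tert-butoxycarbonyl may do to compound 3

The compounds below may be only part of what the source reports. "The series", "measured", "known", "first", "only" and "open" are said of these compounds alone.

In a functional assay on HT-29 cells (Homo sapiens) for inhibition, read by luminescence and CellTiter-Glo, with a stated time of 24 h (on this read-out lower numbers stand for an effect already at smaller amounts and higher numbers for an effect only at larger amounts of compound), compound 1 `CCn1nc(C(=O)N[C@H]2COc3ccccc3N(C)C2=S)nc1Cc1ccccc1` gives 17 nM and compound 2 `CCCn1nc(C(=O)N[C@H]2COc3ccccc3N(C)C2=S)nc1Cc1ccccc1` gives 288 nM. Compound 3 `CN1C(=S)[C@@H](NC(=O)c2nc(Cc3ccccc3)n(C3CCN(C(=O)OC(C)(C)C)CC3)n2)COc2ccccc21` reads > 10000 nM, which is a limit of the assay and not a number. Compound 4 `CN1C(=S)[C@@H](NC(=O)c2nc(Cc3ccccc3)n(C3CCNCC3)n2)COc2ccccc21` carries hydrogen in place of tert-butoxycarbonyl on an amine nitrogen in a ring. Among the measured compounds shown here, only one measured step offers guidance: the group on the aromatic nitrogen also changes between the first two compounds, and a single added methyl there gives a 17-fold higher number from compound 1 to compound 2 (1.23 log units; beyond the scatter). Removing a much larger piece from that group is therefore expected to matter as well. The expected change, an at least 12-fold lower number from compound 3 to compound 4 (1.09 log units; beyond the scatter), is large and towards a lower number in this assay. Compound 4 is estimated at 800 nM, within a range of 80 nM to 8000 nM.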

Compound 4, half-maximal effective concentration: 1000 nM
Estimate against measurement, compound 4: 1.3-fold (0.10 log units) below, within the range that was stated.
By their numbers in this assay, from the lowest: compound 1; then compound 2; then compound 4. At a limit, above all of these: compound 3.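

Compound 3 stands at a limit of the assay, which is not a number: the limit of > 10000 nM in this assay, at which 1 of the 4 values shown sits. Taking tert-butoxycarbonyl off the amine nitrogen in the ring gives an at least 10-fold lower number from compound 3 to compound 4 (1.00 log units; beyond the scatter) and so shows that this group accounts for much of the loss. Piperidin-4-yl on the aromatic nitrogen still falls short of the small chains, with a 3.5-fold higher number from compound 2 to compound 4 (0.54 log units; beyond the scatter) and a 59-fold higher number from compound 1 to compound 4 (1.77 log units; beyond the scatter) as the two steps. Open, as far as these compounds go, is whether a smaller group on that amine nitrogen, such as methyl or acetyl, would keep the number of compound 4 or move it.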